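The compounds below may be only part of what the source reports. "The series", "measured", "known", "first", "only" and "open" are said of these compounds alone.

Of the compounds shown here, two on a shared core have been measured in a functional assay, with a stated time of 30 min; a lower number here means a stronger inhibitor, a higher number a weaker inhibitor. Compound 1 `COc1ccc(C2CC(=NOC(=O)c3ccc(Cl)cc3)CC(c3ccc(OC)cc3)N2C)cc1` gives 135000 nM in this assay, and compound 2 `COc1ccc(C2CC(=NOC(=O)c3ccc([N+](=O)[O-])cc3)CC(c3ccc(OC)cc3)N2C)cc1` gives 280000 nM. For the measured compounds named here, compound 2 thus stands at the higher of the two numbers, and the only step between measured compounds, a 2.1-fold higher number from compound 1 to compound 2 (0.32 log units; beyond the scatter), is a modest one. Compound 3 `COc1ccc(C2CC(=NOC(=O)c3ccccc3OC(C)=O)CC(c3ccc(OC)cc3)N2C)cc1` differs from compound 2 by 2-acetoxyphenyl in place of 4-nitrophenyl on a carbonyl carbon. Going by the values given here, no measured step bears directly on this exchange; the single step available replaces chloro with nitro on the same aromatic ring and shows only that such a swap shifts the number modestly. On that footing the step of a 1.4-fold lower number from compound 2 to compound 3 (0.15 log units; within the scatter) is expected to be small, staying within or near the scatter. Compound 3 is therefore estimated at 200000 nM, with a likely range from 60000 nM to 650000 nM.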

Compound 3, half-maximal inhibitory concentration: 350000 nM
Beside the measured number, compound 3's estimate is 1.8-fold (0.24 log units) below it; the measured number falls inside the stated range.
By their numbers in this assay, from the lowest: compound 1; then compounds 2 and 3 (each within the scatter of the next).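

In this assay, for the compounds shown here, a change of the whole aryl group on the carbonyl carbon, 2-acetoxyphenyl in place of 4-nitrophenyl, gives a 1.3-fold higher number from compound 2 to compound 3 (0.10 log units; within the scatter) and so does not separate these two groups, although the earlier chloro-to-nitro step had been the only guide at this position. Set against 4-chlorophenyl, the same 2-acetoxyphenyl gives a 2.6-fold higher number from compound 1 to compound 3 (0.41 log units; beyond the scatter) and resembles the nitro step in size and direction, leaving compound 1 with the lowest number of the three. Nothing measured here explains why the 4-chlorophenyl compound differs from the other two.

On these data alone, whether a 4-aminophenyl or a 4-carboxyphenyl group on the same carbonyl carbon would bring the number far below this high range remains open. Also open, as far as these compounds go, is whether a 2-hydroxyphenyl group would read as 2-acetoxyphenyl does.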